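Three Limits and an Untested Chlorophenyl Analogue

The compounds below may be only part of what the source reports. "The series", "measured", "known", "first", "only" and "open" are said of these compounds alone.

compound 1 `COc1cccc(/C=C/C(=O)c2sc(Nc3cccc(C)c3)nc2C)c1` — > 25000 nM
compound 2 `COc1cccc(/C=C/C(=O)c2sc(Nc3ccc(Cl)cc3)nc2C)c1` — > 25000 nM
compound 3 `COc1cc(/C=C/C(=O)c2sc(Nc3ccc(Cl)cc3)nc2C)cc(OC)c1OC` — > 25000 nM

In a functional assay on PC-3 cells (Homo sapiens) for cytotoxicity, read by MTT assay (a lower number here means a stronger inhibitor, a higher number a weaker inhibitor), compound 1 gives > 25000 nM, which is a limit of the assay and not a number. Compound 2 gives > 25000 nM, also a limit. Compound 3 gives > 25000 nM, again a limit. Compound 1 thus stands at the limit of > 25000 nM in this assay, at which 3 of the 3 values shown sit, where every value shown sits, and the step that the two limits leave unreadable from compound 1 to compound 2 cannot be read from these two limits. Compound 4, `Cc1cccc(Nc2nc(C)c(C(=O)/C=C/c3ccc(Cl)cc3)s2)c1`, differs from compound 1 by 4-chlorophenyl in place of 3-methoxyphenyl on a double-bonded chain carbon bound to a double-bonded chain carbon. Within the data shown here, no measured step touches that position; the single measured step alters the group on the nitrogen and is itself unreadable. Compound 2 and compound 3 both sit at the limit as well. The expectation for compound 4 is therefore no step beyond the scatter from compound 1 in this assay, and most likely yet another limit. Compound 4 is estimated at 30000 nM, with a range from 10000 nM to 100000 nM. The estimated step that the limit leaves unreadable from compound 1 to compound 4 is expected to be flat.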

Compound 4, half-maximal inhibitory concentration: > 25000 nM
Compound 4: no number, only a limit; the forecaster's own chance of this, stated with the estimate: 80%; the middle value lies beyond the limit too.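

In this assay compound 4 gives > 25000 nM, which is a limit and not a number. No step from compound 1 to compound 4 can be read, and all compounds shown sit together: the limit of > 25000 nM in this assay, at which 4 of the 4 values shown sit.

The compounds shown leave open which change to the groups on the shared core, if any, gives a readable value in this assay.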